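Mirror-Image Pair on a Meta-Methylphenyl Core

The source may report more compounds than this note shows. Statements on the series, on what has been measured and on what is new or still open speak of the compounds shown alone.

Compound 1 `CC1=NN(c2ccccc2)C(=O)[C@@]12C(=O)C=CC[C@H]2c1ccc(C)cc1` gives 5210 nM in a functional assay on HCT-116 cells (Homo sapiens) for inhibition, read by MTT assay, with a stated time of 72 h; on this read-out higher numbers stand for weaker inhibition and lower numbers for stronger inhibition.
Compound 2 `CC1=NN(c2ccccc2)C(=O)[C@]12C(=O)C=CC[C@@H]2c1ccc(C)cc1` gives 5800 nM.
Compound 3 `CC1=NN(c2ccccc2)C(=O)[C@@]12C(=O)C=CC[C@H]2c1cccc(C)c1` gives 5820 nM.

Among these three, compound 3 carries the highest number, yet its gaps to compound 2 and to compound 1 lie within the scatter, so the three cannot be told apart in this assay. Compound 4 `CC1=NN(c2ccccc2)C(=O)[C@]12C(=O)C=CC[C@@H]2c1cccc(C)c1` has not yet been measured; it differs from compound 3 in this way: the two compounds have the same atoms and bonds and differ only in configuration as drawn: 2 of 2 stereo elements differ (all stereocentres are inverted: mirror images); a stereocentre at a saturated ring carbon is drawn R in compound 3 and S in compound 4; a stereocentre at a saturated ring carbon is drawn S in compound 3 and R in compound 4. Within the data shown here, one measured step bears on it, the mirror-image pair in which a 1.1-fold higher number from compound 1 to compound 2 (0.05 log units; within the scatter); that pair is the only direct precedent because of the fact that compounds 1 and 2 differ only in the configuration as drawn. That step stayed within the scatter, and the step of a 1.0-fold higher number from compound 3 to compound 4 (0.01 log units; within the scatter) is therefore expected to show no change beyond the scatter. Compound 4 is estimated at 6000 nM, with a range from 3000 nM to 12000 nM.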

Compound 4, half-maximal inhibitory concentration: 5490 nM
The estimate for compound 4 lay 1.1-fold (0.04 log units) above the measured number; low and high end bracket the measured number.
By their numbers in this assay, from the lowest: compounds 1, 4, 2 and 3 (each within the scatter of the next).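

With a 1.1-fold lower number from compound 3 to compound 4 (0.03 log units; within the scatter), a second mirror-image pair stays within the scatter in this assay, so inverting both stereocentres shows no change beyond the scatter with a 3-methylphenyl group, as with a 4-methylphenyl group. The swap to 3-methylphenyl can now also be read in the mirror-image series, through a 1.1-fold lower number from compound 2 to compound 4 (0.02 log units; within the scatter), and the two readings agree: the same change on two cores in this assay, a 1.1-fold higher number (0.05 log units; within the scatter) from compound 1 to compound 3 and a 1.1-fold lower number (0.02 log units; within the scatter) from compound 2 to compound 4, 1.2-fold (0.07 log units) apart, within the scatter of two such steps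

The compounds shown leave open how an amine, a carboxylic acid or a longer chain would read in place of the methyl on this phenyl ring. Also open, on these data alone, is what inverting only one of the two stereocentres would do.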